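Swapping an Amide Substituent in a Weakly Cytotoxic Series

A few compounds are considered here, and "the series" means these few. Any claim that something is new, unique, unknown or untested is made for them only; others in the source may bear on it.

Of the compounds shown here, three have been tested in a functional assay on ECa-109 cells (Homo sapiens) for cytotoxicity, read by MTT assay, with a stated time of 72 h; a lower number here means a stronger inhibitor, a higher number a weaker inhibitor. Compound 1 `COc1ccc(/C=C/C(=O)OCC(=O)Nc2ccccc2)cc1OC` reaches only a limit of the assay, > 200000 nM. Compound 2 `CCOc1ccc(COc2c(OC)cc(/C=C/C(=O)OCC(=O)Nc3ccc(Cl)cc3)cc2OC)cc1` likewise reaches only a limit, > 200000 nM. Among the compounds with values here, compound 3 `O=C(COC(=O)/C=C/c1ccc(O)c(O)c1)Nc1ccc(Cl)cc1` is the one compound with a measured number, giving 175000 nM in this assay. It stands alone as the only number shown; the other two values sit at the limit of > 200000 nM in this assay, at which 2 of the 3 values shown sit. Within the data shown here, no step between measured compounds can be read from these data. Compound 4 `O=C(COC(=O)/C=C/c1ccc(O)c(O)c1)NN1CCOCC1` differs from compound 3 by morpholin-4-yl in place of 4-chlorophenyl on an amide-type nitrogen. Among the measured compounds shown here, with no measured step to lean on, the expected step of a 1.1-fold higher number from compound 3 to compound 4 (0.06 log units; within the scatter) is none beyond the usual scatter, and the assay may again report only a limit. Compound 4 is therefore expected to give about 200000 nM in this assay, with a range from 90000 nM to 450000 nM.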

Compound 4, half-maximal inhibitory concentration: > 200000 nM
Compound 4: only a limit was reported (the forecaster's own chance of this, stated with the estimate: 55%); the middle value lies on the limit itself.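

In this assay compound 4 reports only a limit, > 200000 nM. Morpholin-4-yl in place of 4-chlorophenyl on an amide-type nitrogen gives the only step readable here, an at least 1.1-fold higher number from compound 3 to compound 4 (0.05 log units; that floor lies within the scatter), so this swap is not shown to move the number beyond the scatter, and its true size cannot be read. Most of the series now rests on that limit: the limit of > 200000 nM in this assay, at which 3 of the 4 values shown sit.

As far as these compounds go, whether another group on this nitrogen would give a measured number stays open. A piperidin-1-yl or a dimethylamino group in this place could test that.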